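The source may report more compounds than this note shows. Statements on the series, on what has been measured and on what is new or still open speak of the compounds shown alone.

Among the measured compounds shown here, the two compounds measured so far share a core and differ only in their outer parts. Compound 1 `O=C(/C=C/c1ccc(Cn2cc(Nc3ncc(Cl)c(Nc4ccc(F)cc4)n3)cn2)cc1)NO` gives 1030 nM in a functional assay on K562 cells (Homo sapiens) for antiproliferative activity, read by MTT assay, with a stated time of 48 h; on this read-out lower numbers stand for stronger inhibition and higher numbers for weaker inhibition. Compound 2 `COc1ccc(Nc2nc(Nc3cnn(CCCCCCC(=O)NO)c3)ncc2Cl)cc1` gives 620 nM in this assay; its number and that of compound 1 lie within the scatter of each other, so the two cannot be told apart on what has been measured. For the measured compounds named here, compound 3 `O=C(CCCCCCn1cc(Nc2ncc(Cl)c(Nc3ccc(Cl)cc3)n2)cn1)NO` is not yet measured and keeps the chain of compound 2, changing only one point on the core: chloro in place of methoxy on an aromatic carbon. The change sits on an aromatic carbon of a six-membered aromatic ring of carbon only, para to a large group. Going by the values given here, no pair of measured compounds differs in one place, so nothing here shows how such a swap moves the number. On that basis the step from compound 2 to compound 3 is expected to stay within the scatter in this assay, with at most a slight lowering, and is estimated as a 1.1-fold lower number from compound 2 to compound 3 (0.05 log units; within the scatter). Compound 3 is therefore expected to give about 550 nM in this assay, within a range of 220 nM to 1400 nM.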

Compound 3, half-maximal inhibitory concentration: 320 nM
The estimate for compound 3 lay 1.7-fold (0.24 log units) above the measured number; the range from low to high includes it.
By their numbers in this assay, from the lowest: compounds 3, 2 and 1 (each within the scatter of the next, the first and the last beyond it).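

In this assay, among the compounds shown here, the first step that can be read at one place shows that chloro in place of methoxy, on an aromatic carbon of a six-membered aromatic ring of carbon only and para to a large group, gives a 1.9-fold lower number from compound 2 to compound 3 (0.29 log units; within the scatter) with the rest of the structure held constant. The (4-methoxyphenyl)amino and (4-chlorophenyl)amino forms therefore cannot be told apart on this read-out, even though the exchange removes the oxygen and the one hydrogen-bond acceptor counted in the methoxy group. Nothing measured here explains this outcome or connects it to any property of either group.

The compounds shown leave open whether a different group at this same place, such as an amine, a carboxylic acid or a trifluoromethyl group, would move the number beyond the scatter, since methoxy and chloro are the only two groups compared there. For the compounds shown here, they also leave open whether the swap would behave in the same way with a longer chain in place of the one shared by compound 2 and compound 3.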